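Sulfonyl aryl swap within a shared quinoline-free core series

A few compounds are considered here, and "the series" means these few. Any claim that something is new, unique, unknown or untested is made for them only; others in the source may bear on it.

Measured so far:
Compound 1, `O=S(=O)(c1cc(Cl)cc(Cl)c1)c1cnc2cc(F)ccc2c1-c1ccccc1F`: 0.93 mL/min
Compound 2, `O=S(=O)(c1cc(Cl)cc(Cl)c1)c1cnc2cc(F)ccc2c1-c1ccc(Cl)cc1`: 0.13 mL/min
Compound 3, `O=S(=O)(c1ccc(F)c(Cl)c1)c1cnc2cc(F)ccc2c1-c1ccc(F)cc1`: 0.69 mL/min

In an ADME assay on microsomes from liver (Homo sapiens) for metabolic stability, tested at 2.5 uM (on this read-out higher numbers stand for fast clearance and lower numbers for slow clearance), compound 3 gives 0.69 mL/min, the second highest of the three numbers. Its nearest neighbour is compound 1, which sits within the scatter of it, while compound 2 lies well below, beyond the scatter.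

Compound 4, `O=S(=O)(c1cc(Cl)cc(Cl)c1)c1cnc2cc(F)ccc2c1-c1ccc(F)cc1`, is not yet measured. It differs from compound 3 in one place: 3,5-dichlorophenyl in place of 3-chloro-4-fluorophenyl on a sulfonyl sulfur.

Within the data shown here, the only measured step, a 7.2-fold lower number from compound 1 to compound 2 (0.85 log units; beyond the scatter), concerns the other aromatic group, the one on the core carbon, and not the group on the sulfonyl sulfur; so no step directly bears on the present change. Compounds 1 and 2 both carry the 3,5-dichlorophenyl that enters here, and their values in this assay span from the highest to the lowest of the set, so that group alone fixes nothing. Among the measured compounds shown here, with no direct precedent, the change is expected to move this assay little, and compound 4 is expected to stay within the scatter of compound 3, with the expected step of a 1.3-fold lower number from compound 3 to compound 4 (0.10 log units; within the scatter).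

Compound 4 is therefore estimated at 0.55 mL/min, with a range from 0.18 mL/min to 1.3 mL/min.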

Compound 4, intrinsic clearance in a liver preparation (reported as CLH), per the amount of preparation that the assay uses: 0.18 mL/min
Estimate against measurement, compound 4: 3.1-fold (0.49 log units) above, and the stated range covers the measured number.
By their numbers in this assay, from the lowest: compounds 2 and 4 (each within the scatter of the next); then compounds 3 and 1 (each within the scatter of the next).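

In this assay, among these compounds, the group on the sulfonyl sulfur proves able to shift the number on its own: 3,5-dichlorophenyl in place of 3-chloro-4-fluorophenyl gives a 3.8-fold lower number from compound 3 to compound 4 (0.58 log units; beyond the scatter) with the 4-fluorophenyl on the core carbon held fixed, the first measured step at this position. With 3,5-dichlorophenyl on the sulfonyl sulfur, fluoro in place of chloro on the aromatic carbon gives only a 1.4-fold higher number from compound 2 to compound 4 (0.14 log units; within the scatter) and so no readable change, while 4-fluorophenyl in place of 2-fluorophenyl gives a 5.2-fold lower number from compound 1 to compound 4 (0.71 log units; beyond the scatter) as a step beyond the scatter, so that among these three compounds only compound 1, the one with 2-fluorophenyl, stands apart. Nothing at hand accounts for either the sulfonyl step or the step on the core carbon.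

The compounds shown leave open whether the step at the sulfonyl sulfur keeps its size when 2-fluorophenyl or 4-chlorophenyl sits on the core carbon. They also leave open how this read-out responds when an amine or a carboxylic acid takes the place of a chlorine on the phenyl group held by the sulfonyl sulfur.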